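A few compounds are considered here, and "the series" means these few. Any claim that something is new, unique, unknown or untested is made for them only; others in the source may bear on it.

In a functional assay on GTL 16 cells (Homo sapiens) for cytotoxicity, with a stated time of 72 h (a lower number here means that less compound is needed, a higher number that more compound is needed for the effect), compound 1 `CCOc1cccc(-c2cc(F)ccc2[C@H]2Cc3nc(N)nc(C)c3C(=O)N2)n1` gives 290 nM and compound 2 `COc1cncc(-c2cc(F)ccc2[C@H]2Cc3nc(N)nc(C)c3C(=O)N2)n1` gives 14 nM, the lower of the two numbers. The next change leads to compound 3 `COc1nc(-c2cc(F)ccc2[C@H]2Cc3nc(N)nc(C)c3C(=O)N2)cs1`, with 2-methoxy-1,3-thiazol-4-yl in place of 6-methoxypyrazin-2-yl on an aromatic carbon. Among the compounds with values here, the only measured step at this place, a 21-fold lower number from compound 1 to compound 2 (1.32 log units; beyond the scatter), is large and shows that the number can move far when this group is replaced. Within the data shown here, no measured step covers a five-membered ring here. A smaller move to a higher number in this assay is expected, estimated as a 2.9-fold higher number from compound 2 to compound 3 (0.46 log units; beyond the scatter). For compound 3, the expected value is 40 nM, with an estimated range of 8 nM to 200 nM.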

Compound 3, half-maximal effective concentration: 190 nM
Beside the measured number, compound 3's estimate is 4.8-fold (0.68 log units) below it; low and high end bracket the measured number.
By their numbers in this assay, from the lowest: compound 2; then compounds 3 and 1 (each within the scatter of the next).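

In this assay, 2-methoxy-1,3-thiazol-4-yl in place of 6-methoxypyrazin-2-yl gives a 14-fold higher number from compound 2 to compound 3 (1.13 log units; beyond the scatter), so the low number of compound 2 does not carry over to every methoxy-bearing aromatic ring at this place. Against 6-ethoxypyridin-2-yl, the same group gives a 1.5-fold lower number from compound 1 to compound 3 (0.18 log units; within the scatter), so these two groups cannot be told apart here. Nothing available accounts for either step. Still open, from the compounds shown here alone, is whether the low number of compound 2 depends on its ring or on its methoxy group. An amine or a longer chain in place of that methoxy group would bear on this.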